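A few compounds are considered here, and "the series" means these few. Any claim that something is new, unique, unknown or untested is made for them only; others in the source may bear on it.

Measured in a functional assay on MCF7 cells (Homo sapiens) for inhibition, read by MTT assay, with a stated time of 48 h, tested at 10 uM; a higher number here means more inhibition of growth at the concentration tested, a lower number less inhibition of growth:
- compound 1 `Cc1oc2c([C@H]3CCN(C)C[C@H]3O)c(O)cc(O)c2c(=O)c1C(O)c1cccc(Cl)c1`: 5%
- compound 2 `Cc1oc2c([C@H]3CCN(C)C[C@H]3O)c(O)cc(O)c2c(=O)c1C(O)c1c(F)cccc1Cl`: 41%
- compound 3 `Cc1oc2c([C@H]3CCN(C)C[C@H]3O)c(O)cc(O)c2c(=O)c1C(O)c1cc(F)cc(F)c1`: 25%

Of these three, compound 3 holds the middle place in this assay, under compound 2 and over compound 1.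

The next analogue, compound 4 `CCOc1ccc(Br)c(C(O)c2c(C)oc3c([C@H]4CCN(C)C[C@H]4O)c(O)cc(O)c3c2=O)c1`, differs from compound 3 in one group: 2-bromo-5-ethoxyphenyl in place of 3,5-difluorophenyl on a saturated chain carbon bound to an aromatic carbon and an oxygen on a saturated carbon.

All three measured steps change this same group. They are a number 36 percentage points higher from compound 1 to compound 2 (beyond the scatter), a number 20 percentage points higher from compound 1 to compound 3 (beyond the scatter) and a number 16 percentage points lower from compound 2 to compound 3 (beyond the scatter), so this position has moved the read-out clearly in both directions. None of the three compounds carries a bromine or an ethoxy group, so the size and direction of the new step are poorly fixed. The 2-chloro-6-fluorophenyl of compound 2, at 41%, gives a weak reason to lean upward.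

The expected change in this assay is small and upward, with no firm step beyond the scatter, and the estimate is a number 5 percentage points higher from compound 3 to compound 4 (within the scatter). Compound 4 is expected at 30%, with an estimated range of 10% to 55%.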

Compound 4, percent growth inhibition at one concentration: 9%
Estimate against measurement, compound 4: 21 percentage points above; the whole stated range lies above it.
By their numbers in this assay, from the lowest: compounds 1 and 4 (each within the scatter of the next); then compound 3; then compound 2.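

In this assay, the 2-bromo-5-ethoxyphenyl group gives a clear loss against the 3,5-difluorophenyl group (a number 16 percentage points lower from compound 3 to compound 4 (beyond the scatter)) and a larger loss against the 2-chloro-6-fluorophenyl group (a number 32 percentage points lower from compound 2 to compound 4 (beyond the scatter)), while against the 3-chlorophenyl group there is no step beyond the scatter (a number 4 percentage points higher from compound 1 to compound 4 (within the scatter)). A halogen on the phenyl ring therefore does not by itself keep the read-out up in this series: all four compounds carry one, and compound 1 and compound 4 stand well under compound 2. No measured information on these compounds accounts for the differences at this position.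

Bromine and ethoxy enter together, so their separate contributions remain unresolved. A phenyl ring carrying an amine or a carboxylic acid, or a longer alkoxy chain in place of ethoxy, lies outside the compounds shown.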